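The compounds below may be only part of what the source reports. "The series", "measured", "known", "first", "only" and "open" are said of these compounds alone.

Measured compounds in an assay on isolated protein for inhibition of Amine oxidase [flavin-containing] A (Homo sapiens), read by fluorescence; on this read-out higher numbers stand for weaker inhibition and lower numbers for stronger inhibition:
compound 1 `COc1cccc(-c2csc(N/N=C/c3ccco3)n2)c1` gives 343 nM;
compound 2 `COc1cccc(-c2csc(N/N=C3\CCC(C)C3)n2)c1` gives 1450 nM;
compound 3 `CCC/C(C)=N/Nc1nc(-c2cccc(OC)c2)cs1` gives 1310 nM.

Among these three, compound 1 holds the lowest number, with compound 3 the nearest and compound 2 the furthest. Both neighbours differ from compound 1 only in the group carried on the nitrogen attached to the shared core: a 4.2-fold higher number from compound 1 to compound 2 (0.63 log units; beyond the scatter) and a 3.8-fold higher number from compound 1 to compound 3 (0.58 log units; beyond the scatter), while the two non-aromatic replacements sit close together, a 1.1-fold lower number from compound 2 to compound 3 (0.04 log units; within the scatter).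

Compound 4 `COc1cccc(-c2csc(N/N=C/c3ccncc3)n2)c1` keeps the hydrazone arrangement of compound 1 and changes the ring on its far end: pyridin-4-yl in place of furan-2-yl on a carbon with a double bond to nitrogen. Going by the values given here, no measured step exchanges one aromatic ring for another at this position; the two steps that do bear on it show that replacing the furan-2-yl ring by a saturated ring or an open chain costs a modest amount in this assay. Because a 4.2-fold higher number from compound 1 to compound 2 (0.63 log units; beyond the scatter) and a 3.8-fold higher number from compound 1 to compound 3 (0.58 log units; beyond the scatter) both accompany exchange of the aromatic ring for a non-aromatic group whereas compound 4 retains an aromatic ring, that loss is expected to be smaller than either of those steps, so the number for compound 4 is expected to move only a little upward, a 1.6-fold higher number from compound 1 to compound 4 (0.21 log units; within the scatter), possibly within the scatter.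

The estimate for compound 4 in this assay is 550 nM, within the range 170 nM to 1800 nM.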

Compound 4, half-maximal inhibitory concentration: 698 nM
Beside the measured number, compound 4's estimate is 1.3-fold (0.10 log units) below it; the range from low to high includes it.
By their numbers in this assay, from the lowest: compound 1; then compounds 4, 3 and 2 (each within the scatter of the next, the first and the last beyond it).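

At this position on a carbon with a double bond to nitrogen, one aromatic ring now replaces another in this assay, and pyridin-4-yl in place of furan-2-yl gives a 2.0-fold higher number from compound 1 to compound 4 (0.31 log units; beyond the scatter), so keeping an aromatic ring here does not by itself preserve the number of compound 1. Compound 4, at 698 nM, also lies within the scatter of compound 3, at 1310 nM, so in this small set the aromatic pyridin-4-yl ring is not separated from the open chain, and only the furan-2-yl ring of compound 1 stands apart from all three other compounds. No measurement available here accounts for this step.

The step changes ring size and hetero atom together, from a five-membered ring with oxygen to a six-membered ring with nitrogen, so the compounds shown cannot assign the change to either one. On these data alone, a thiophen-2-yl ring would keep the five-membered ring with a different hetero atom, while a phenyl or pyridin-3-yl ring would test the six-membered ring, and how either would read in this assay remains open.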